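Swapping the Phthalimide for Phenyl on the Benzoate

The source may report more compounds than this note shows. Statements on the series, on what has been measured and on what is new or still open speak of the compounds shown alone.

Compound 1, `O=C(OCC1CCCN(CCCc2ccccc2)C1)c1ccccc1C(F)(F)F`: 3200 nM
Compound 2, `O=C(OCC1CCCN(CCCc2ccccc2)C1)c1ccccc1F`: 5200 nM
Compound 3, `O=C(OCC1CCCN(CCCc2ccccc2)C1)c1ccccc1N1C(=O)c2ccccc2C1=O`: 1300 nM

In a functional assay with Neuronal acetylcholine receptor; alpha3/beta4 (Homo sapiens) as the target (a higher number here means a weaker inhibitor, a lower number a stronger inhibitor), compound 3 gives the lowest of the three numbers, so it is the strongest inhibitor measured so far. Compound 4, `O=C(OCC1CCCN(CCCc2ccccc2)C1)c1ccccc1-c1ccccc1`, differs from it by a single change: a group of 6 heavy atoms (6 carbon; one six-membered aromatic ring of carbon only) in place of a group of 11 heavy atoms (8 carbon, 1 nitrogen, 2 oxygen; one five-membered non-aromatic ring with 1 hetero atom, one six-membered aromatic ring of carbon only), on an aromatic carbon. Among the measured compounds shown here, two measured steps concern this position. From compound 1 to compound 3, a 2.5-fold lower number from compound 1 to compound 3 (0.39 log units; beyond the scatter); from compound 2 to compound 3, a 4.0-fold lower number from compound 2 to compound 3 (0.60 log units; beyond the scatter). In both, the number fell when the group of 11 heavy atoms entered. The phenyl that enters in compound 4 is a group of 6 heavy atoms, between that group and the trifluoromethyl of compound 1. A modest rise in the number is therefore expected, a 1.7-fold higher number from compound 3 to compound 4 (0.23 log units; within the scatter). The estimated value for compound 4 is 2200 nM, with a likely range from 900 nM to 5000 nM.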

Compound 4, half-maximal inhibitory concentration: 1700 nM
Compound 4: middle estimate off by 1.3-fold (0.11 log units), on the high side; measured number inside the range.
By their numbers in this assay, from the lowest: compounds 3, 4, 1 and 2 (each within the scatter of the next, the first and the last beyond it).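

In this assay, phenyl carries no hydrogen-bond acceptors, yet the number stays within the scatter when it replaces the larger group, a 1.3-fold higher number from compound 3 to compound 4 (0.12 log units; within the scatter), so those acceptors are not needed at this aromatic carbon to keep the number low. Phenyl clearly improves on fluoro, a 3.1-fold lower number from compound 2 to compound 4 (0.49 log units; beyond the scatter), while its step from trifluoromethyl stays within the scatter, a 1.9-fold lower number from compound 1 to compound 4 (0.27 log units; within the scatter). Nothing available explains these numbers. Still open, as far as these compounds go, is how an amine, a carboxylic acid or a longer chain would behave at this aromatic carbon, and whether a methoxy group on the phenyl would shift the number.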